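Triazolylphenyl sulfonamides: cytotoxicity, methyl to chloro step

A few compounds are considered here, and "the series" means these few. Any claim that something is new, unique, unknown or untested is made for them only; others in the source may bear on it.

Measured so far:
compound 1 `O=c1[nH]cc(S(=O)(=O)Nc2ccccc2-c2cn(-c3cccc(Cl)c3)nn2)c(=O)[nH]1`: > 100000 nM
compound 2 `Cc1ccc(-n2cc(-c3cccc(NS(=O)(=O)c4c[nH]c(=O)[nH]c4=O)c3)nn2)cc1`: 23100 nM

In an ADME assay on L02 cells (Homo sapiens) for cytotoxicity, read by MTT assay, with a stated time of 24 h (on this read-out higher numbers stand for lower toxicity in this test and lower numbers for higher toxicity in this test), compound 2 gives 23100 nM. Compound 1 returns > 100000 nM, which is a limit of the assay and not a number. Compound 1 therefore sits at the limit of > 100000 nM in this assay, at which 1 of the 2 values shown sits. Within the data shown here, compound 2 thus holds the only numeric value; the one other entry is a limit, so no measured step between two numbers exists.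

Compound 3 `O=c1[nH]cc(S(=O)(=O)Nc2cccc(-c3cn(-c4ccc(Cl)cc4)nn3)c2)c(=O)[nH]1` is the next compound to go into this assay. It differs from compound 2 by chloro in place of methyl on an aromatic carbon, para to a large group. Among the measured compounds shown here, with no measured step of one change to lean on, the change from compound 2 to compound 3 is expected to stay within the scatter, estimated as a 1.2-fold lower number from compound 2 to compound 3 (0.06 log units; within the scatter). For compound 3 the expected value is 20000 nM, estimated within 7000 nM to 60000 nM.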

Compound 3, half-maximal cytotoxic concentration: 9860 nM
Compound 3: middle estimate off by 2.0-fold (0.31 log units), on the high side; the measured number falls inside the stated range.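

In this assay, among these compounds, the change from 4-methylphenyl to 4-chlorophenyl gives a 2.3-fold lower number from compound 2 to compound 3 (0.37 log units; beyond the scatter), the first step between two numbers. The substituent para to a large group therefore registers in this test: exchanging a single heavy atom, with no change in the count of hydrogen-bond donors or acceptors, shifts the read-out modestly towards higher toxicity. Compound 1 remains a limit of the assay and not a number, and it differs from compound 3 in more than one place, so it adds no step: the limit of > 100000 nM in this assay, at which 1 of the 3 values shown sits.

On these data alone, whether this shift is particular to chloro or would recur with other groups on the same carbon remains open; a fluoro, methoxy or carboxylic acid group there would test it. A single step also cannot show whether the same change would act alike on the core of compound 1.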